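The source may hold more compounds than are shown below. What is called first, only, known or untested is meant among the compounds shown, and "the series" means these compounds.

Compound 1 `O=C(c1cccc(Cl)c1)N1CCC(NS(=O)(=O)c2cc(S(=O)(=O)c3ccccc3)ccc2C(F)(F)F)CC1` gives 870 nM in an assay on U2OS cells for inhibition of secreted frizzled-related protein 1 (Homo sapiens), read by a luciferase reporter, with a stated time of 18 h; on this read-out higher numbers stand for an effect only at larger amounts of compound and lower numbers for an effect already at smaller amounts.
Compound 2 `CC(C)(C)OC(=O)N1CCC[C@H]1C(=O)N1CCC(NS(=O)(=O)c2cc(S(=O)(=O)c3ccccc3)ccc2C(F)(F)F)CC1` gives 60 nM in this assay.

Compound 2 holds the lower of the two numbers in this assay. Going by the values given here, the only measured step, a 15-fold lower number from compound 1 to compound 2 (1.16 log units; beyond the scatter), shows that the group on the carbonyl carbon sets the number strongly. Compound 3 `O=C(CC1CCNCC1)N1CCC(NS(=O)(=O)c2cc(S(=O)(=O)c3ccccc3)ccc2C(F)(F)F)CC1` carries the change ((piperidin-4-yl)methyl in place of 1-(tert-butoxycarbonyl)pyrrolidin-2-yl on a carbonyl carbon). Among the compounds with values here, no measured step covers this particular exchange; the one step shows only that this position matters. For compound 3 a weaker outcome than compound 2 is expected, roughly a 6.7-fold higher number from compound 2 to compound 3 (0.82 log units; beyond the scatter). The estimate for compound 3 in this assay is 400 nM, within 100 nM to 2000 nM.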

Compound 3, half-maximal effective concentration: 210 nM
Estimate against measurement, compound 3: 1.9-fold (0.28 log units) above, within the range that was stated.
By their numbers in this assay, from the lowest: compound 2; then compound 3; then compound 1.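

In this assay, (piperidin-4-yl)methyl on the carbonyl carbon ranks in the middle of the three groups: a 3.5-fold higher number from compound 2 to compound 3 (0.54 log units; beyond the scatter) and a 4.1-fold lower number from compound 1 to compound 3 (0.62 log units; beyond the scatter). This position therefore accepts a non-aromatic ring without tert-butoxycarbonyl and still gives a lower number than 3-chlorophenyl, although 1-(tert-butoxycarbonyl)pyrrolidin-2-yl remains ahead. No available evidence explains either step. The exchange alters ring size, heavy-atom count and hydrogen-bond donor count together, so the contribution of each remains unresolved. Also open, on these data alone, is how an unsubstituted pyrrolidin-2-yl group or a carboxylic acid at this position would compare.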